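The compounds below may be only part of what the source reports. "The series", "measured", "known", "first", "only" and "open" are said of these compounds alone.

Measured in a functional assay on U-87MG ATCC cells (Homo sapiens) for cytotoxicity, read by MTT assay, with a stated time of 72 h; on this read-out higher numbers stand for weaker inhibition and lower numbers for stronger inhibition:
Compound 1 `COc1ccc(OC)c(/C=N/NC(=O)Nc2ccc(Oc3ccnc(-c4nncn4CCN(C)C)c3)c(F)c2)c1` gives 6400 nM.
Compound 2 `COc1ccc(/C=N/NC(=O)Nc2ccc(Oc3ccnc(-c4nncn4CCN(C)C)c3)c(F)c2)c(OC)c1` gives 12600 nM.
Compound 3 `COc1ccc(/C=N/NC(=O)Nc2ccc(Oc3ccnc(-c4nncn4CCN(C)C)c3)c(F)c2)c(OC)c1OC` gives 7650 nM.

Compound 1 has the lowest number of the three, but all three sit within the usual scatter of one another: a 2.0-fold higher number from compound 1 to compound 2 (0.29 log units; within the scatter), a 1.2-fold higher number from compound 1 to compound 3 (0.08 log units; within the scatter), and a 1.6-fold lower number from compound 2 to compound 3 (0.22 log units; within the scatter). Moving or adding a methoxy group on this aromatic ring therefore produced nothing that can be told apart from measurement noise, so none of the three can be called the strongest.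

Compound 4 `CN(C)CCn1cnnc1-c1cc(Oc2ccc(NC(=O)N/N=C/c3cccc(Cl)c3Cl)cc2F)ccn1` is built from compound 1 by a different kind of change: 2,3-dichlorophenyl in place of 2,5-dimethoxyphenyl on a carbon with a double bond to nitrogen. The ring loses its methoxy groups and carries chlorine instead. Among the compounds with values here, none of the measured steps swaps methoxy for chlorine, so they give only indirect guidance; what they do show is that this ring tolerated changes of its methoxy pattern without any shift beyond the scatter. On that basis no step beyond the scatter is expected in this assay, and the step of a 1.0-fold higher number from compound 1 to compound 4 (0.01 log units; within the scatter) is an estimate rather than a measurement. Compound 4 is expected to give about 6500 nM, with a range from 2000 nM to 20000 nM.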

Compound 4, half-maximal inhibitory concentration: 13200 nM
Compound 4: middle estimate off by 2.0-fold (0.31 log units), on the low side; the measured number falls inside the stated range.
By their numbers in this assay, from the lowest: compounds 1, 3, 2 and 4 (each within the scatter of the next, the first and the last beyond it).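

In this assay, within the data shown here, the 2,3-dichlorophenyl group gives the first step at this position that lies beyond the scatter, though only a modest one (a 2.1-fold higher number from compound 1 to compound 4 (0.31 log units; beyond the scatter)). The same group cannot be told apart from the two other methoxy-bearing rings (a 1.7-fold higher number from compound 3 to compound 4 (0.24 log units; within the scatter); a 1.0-fold higher number from compound 2 to compound 4 (0.02 log units; within the scatter)), so the swap from methoxy to chlorine separates compound 4 from compound 1 alone and does not set it apart from the whole methoxy series. Nothing measured here accounts for the step from compound 1 to compound 4.

The four compounds cannot separate the effect of adding chlorine from that of removing methoxy, as no ring here carries both groups or neither. Also open is where a plain phenyl, or a phenyl carrying a single chlorine, a nitrile or an amine, would fall among these values.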